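Swapping (tert-butoxy)oxy for methyl on a ring carbon

The source may report more compounds than this note shows. Statements on the series, on what has been measured and on what is new or still open speak of the compounds shown alone.

Only one of the two tested compounds offers any anchor, and it is not a number. In a functional assay on MEL28 cells (Homo sapiens) for cytotoxicity, read by sulforhodamine B assay, with a stated time of 72 h (a higher number here means a weaker inhibitor of growth, a lower number a stronger inhibitor of growth), compound 1 `C=C1[C@H](O)C[C@@H]2[C@](C)(CCC[C@]2(C)C(=O)OC)[C@H]1CCc1ccc2c(OC(C)=O)ccc(OC(C)=O)c2c1` gives "not determined" (no result reported), so it provides no reference point. In this assay compound 2 `COC(=O)[C@@]1(C)CCC[C@]2(C)C(CCc3ccc4c(OC)ccc(OC)c4c3)=C(OOC(C)(C)C)CC[C@@H]12` reaches only a limit, > 18600 nM, and not a number.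

Compound 3 `COC(=O)[C@@]1(C)CCC[C@]2(C)C(CCc3ccc4c(OC)ccc(OC)c4c3)=C(C)CC[C@@H]12` keeps the shared core of compound 2 but carries methyl in place of (tert-butoxy)oxy on a double-bonded ring carbon. Going by the values given here, no measured step shows what this exchange does in this assay. Any expectation therefore rests on compound 2 alone and on (the limit of > 18600 nM in this assay, at which 1 of the 2 values shown sits), which leaves the size of the change open and allows a measurable number only on the stronger side. The expected step of an at least 1.2-fold lower number from compound 2 to compound 3 (0.09 log units; that floor lies within the scatter) is modest, towards stronger growth inhibition if it appears at all. Compound 3 is estimated at 15000 nM, with an expected range from 5000 nM to 24000 nM, and it may also return only a limit.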

Compound 3, concentration for 50% growth inhibition: > 6700 nM
Compound 3 was reported as a limit; the forecaster's own chance of this, stated with the estimate: 55%; the middle value lies beyond the limit too.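

In this assay, compound 2 and compound 3 both return only limits, so no step can be read for the exchange of (tert-butoxy)oxy for methyl. The compounds shown leave open the size and direction of any change in growth inhibition with this exchange, and where either compound would stand as a single number.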